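The source may hold more compounds than are shown below. What is called first, only, known or untested is meant among the compounds shown, and "the series" means these compounds.

Compound 1 `CSCC(=O)N1CCN(c2nc(=O)c3cc(C(F)(F)F)cc([N+](=O)[O-])c3s2)CC1`, compound 2 `O=C(C1CC1)N1CCN(c2nc(=O)c3cc(C(F)(F)F)cc([N+](=O)[O-])c3s2)CC1` and compound 3 `O=C(c1cccc(F)c1)N1CCN(c2nc(=O)c3cc(C(F)(F)F)cc([N+](=O)[O-])c3s2)CC1` share one core and differ only in the group on the carbonyl carbon. In an ADME assay on Vero cells (Chlorocebus sabaeus) for cytotoxicity, read by MTT assay, with a stated time of 72 h (a higher number here means that more compound is tolerated, a lower number that less compound is tolerated), compound 1 reaches only a limit, > 125000 nM. Compound 2 likewise reaches only a limit in this assay, > 125000 nM. Compound 3 also gives only a limit in this assay, > 125000 nM. The steps a step that the two limits leave unreadable from compound 1 to compound 2, a step that the two limits leave unreadable from compound 1 to compound 3 and a step that the two limits leave unreadable from compound 2 to compound 3 are therefore unreadable, all three values resting at the limit of > 125000 nM in this assay, at which 3 of the 3 values shown sit. Compound 4 `O=C(C1CCC1)N1CCN(c2nc(=O)c3cc(C(F)(F)F)cc([N+](=O)[O-])c3s2)CC1` differs from compound 3 by cyclobutyl in place of 3-fluorophenyl on a carbonyl carbon. With every measured analogue at the limit of > 125000 nM in this assay, at which 3 of the 3 values shown sit, no step beyond the scatter is expected in this assay for this change. Compound 4 is therefore estimated at 150000 nM, between 90000 nM and 400000 nM. That estimate means an expected step that the limit leaves unreadable from compound 3 to compound 4.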

Compound 4, half-maximal cytotoxic concentration: > 125000 nM
Compound 4 ended at the assay's limit (the forecaster's own chance of this, stated with the estimate: 85%); the middle value does not contradict the limit.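

Going by these compounds alone, compound 4, like compound 1, compound 2 and compound 3, gives only a limit, so no step among them can be read in this assay: the limit of > 125000 nM in this assay, at which 4 of the 4 values shown sit. The compounds shown leave open whether the group on the carbonyl carbon changes the result in this assay at all.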